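The source may hold more compounds than are shown below. What is called first, only, known or untested is meant among the compounds shown, and "the series" means these compounds.

Series notes. In a functional assay on MCF7 cells (Homo sapiens) for cytotoxicity, read by MTT assay, with a stated time of 72 h (on this read-out lower numbers stand for stronger inhibition and higher numbers for weaker inhibition), compound 1 `COc1ccc(-c2cc(=O)c3c(O)cc(OCCCCN4CCN(C)CC4)c(OC)c3o2)cc1` gives 3980 nM, and compound 2 `COc1c(OCCCCN2CCN(C)CC2)cc(O)c2c(=O)cc(-c3ccc(Br)cc3)oc12` gives 3210 nM. Among the compounds with values here, the one measured step between them, a 1.2-fold lower number from compound 1 to compound 2 (0.09 log units; within the scatter), concerns the aryl substituent rather than the amine chain. Compound 3 `O=c1cc(-c2ccccc2)oc2c(OCCCN3CCCC3)c(OCc3ccccc3)cc(O)c12` gives 2230 nM in this assay, within the scatter of both compound 2 and compound 1. Compound 4 `CCN(CC)CCCCOc1c(OCc2ccccc2)cc(O)c2c(=O)cc(-c3ccccc3)oc12` differs from compound 3 by (diethylamino)methyl in place of pyrrolidin-1-yl on a saturated chain carbon, three bonds along the chain from an oxygen on an aromatic ring. Within the data shown here, no measured step touches the terminal amine, so the step between compound 1 and compound 2 does not bear on this change, and nothing in the data points either way. The expectation for this assay is therefore a step no larger than the scatter, a 1.1-fold higher number from compound 3 to compound 4 (0.03 log units; within the scatter). Compound 4 is estimated at 2400 nM in this assay, with a range from 1000 nM to 5500 nM.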

Compound 4, half-maximal inhibitory concentration: 1920 nM
The estimate for compound 4 lay 1.3-fold (0.10 log units) above the measured number, and the stated range covers the measured number.
By their numbers in this assay, from the lowest: compounds 4, 3, 2 and 1 (each within the scatter of the next, the first and the last beyond it).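

Within the data shown here, at the terminal amine, the step of a 1.2-fold lower number from compound 3 to compound 4 (0.07 log units; within the scatter) in this assay gives the first reading at this position: 4-(diethylamino)butyl and 3-(pyrrolidin-1-yl)propyl are not told apart, so opening the ring and lengthening the chain together leave the number within the scatter. No measurement on hand offers an explanation for this result.

The step changes the ring and the chain length at once, and a 4-(pyrrolidin-1-yl)butyl group would separate the two. As far as these compounds go, whether a morpholine or a primary amine at the chain end would also stay within the scatter remains open.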